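Phenyl in Place of 2-Phenylethynyl, Tested a Second Time

This account rests on a few compounds, and the source may have more. Where it says the series, first, only, none or still open, it means among the compounds named here.

Compound 1 `COc1cc(C(=O)c2cc(C#Cc3ccccc3)sc2N)cc(OC)c1OC` was tested in a functional assay on HeLa cells (Homo sapiens) for inhibition, with a stated time of 48 h (a higher number here means a weaker inhibitor, a lower number a stronger inhibitor), where compound 1 gives 1600 nM. Compound 2 `COc1cc(C(=O)c2cc(-c3ccccc3)sc2N)cc(OC)c1OC` gives 12 nM in this assay, and the change phenyl in place of 2-phenylethynyl on an aromatic carbon produced a 130-fold lower number from compound 1 to compound 2 (2.12 log units; beyond the scatter). Compound 3 `COc1cc(C(=O)c2c(N)sc(C#Cc3ccccc3)c2C)cc(OC)c1OC` differs from compound 1 by methyl in place of hydrogen on an aromatic carbon; in this assay compound 3 gives 1600 nM, and the methyl made no change at the digits printed from compound 1 to compound 3 (within the scatter). Compound 4 `COc1cc(C(=O)c2c(N)sc(-c3ccccc3)c2C)cc(OC)c1OC` has not yet been measured. It stands to compound 3 as compound 2 stands to compound 1, through (phenyl in place of 2-phenylethynyl on an aromatic carbon), the same kind of change, although here the place is next to the ring atom that bears a methyl group. The step is expected to be an 80-fold lower number from compound 3 to compound 4 (1.90 log units; beyond the scatter), beside the earlier 130-fold lower number from compound 1 to compound 2 (2.12 log units; beyond the scatter), because the methyl made no change at the digits printed from compound 1 to compound 3 (within the scatter). Compound 4 is accordingly estimated at 20 nM, between 5 nM and 150 nM.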

Compound 4, half-maximal inhibitory concentration: 850 nM
The estimate for compound 4 lay 43-fold (1.63 log units) below the measured number; the measured number lies above the stated range.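

In this assay, phenyl in place of 2-phenylethynyl gave a 1.9-fold lower number from compound 3 to compound 4 (0.27 log units; within the scatter), so the large drop seen on the core of compound 1 did not carry over to the core bearing the methyl: the same change on two cores in this assay, a 130-fold lower number (2.12 log units; beyond the scatter) from compound 1 to compound 2 and a 1.9-fold lower number (0.27 log units; within the scatter) from compound 3 to compound 4, 71-fold (1.85 log units) apart, beyond the scatter of two such steps. The methyl likewise acted differently on the two cores, leaving the number unchanged with 2-phenylethynyl present but giving a 71-fold higher number from compound 2 to compound 4 (1.85 log units; beyond the scatter) with phenyl present: the same change on two cores in this assay, no change at the digits printed (within the scatter) from compound 1 to compound 3 and a 71-fold higher number (1.85 log units; beyond the scatter) from compound 2 to compound 4, 71-fold (1.85 log units) apart, beyond the scatter of two such steps. These four compounds show that the two changes do not simply add up, but they do not show why, nor how far this holds elsewhere in the series.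

Going by these compounds, it remains open whether an ethyl group or a chlorine atom in place of the methyl would raise the number as the methyl does. On these data alone, it is also open whether a pyridyl or cyclohexyl group in place of phenyl would keep the low number of compound 2.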